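The compounds below may be only part of what the source reports. "The series", "measured", "known", "first", "only" and "open" are said of these compounds alone.

Compound 2 `CC1=C(N2CC2)C(=O)C(Cc2ccccc2)=C(N2CC2)C1=O` is one of three quinone-type compounds measured in a functional assay on L1210 cells (Mus musculus), with a stated time of 1 days (a higher number here means a more potent compound, by a factor of ten per unit of this negative logarithm, a lower number a less potent compound), where compound 2 gives 4.26. This is the lowest of the three numbers. Compound 1 `CCCC1=C(N2CC2)C(=O)C(C(COC(N)=O)OC)=C(N2CC2)C1=O` gives 4.64, and compound 3 `CCC1=C(N2CC2)C(=O)C(CCOC(N)=O)=C(N2CC2)C1=O` gives 4.88; both lie above compound 2 by more than the usual scatter, compound 3 by the wider margin.

Compound 4 `CC(=O)C1=C(N2CC2)C(=O)C(C)=C(N2CC2)C1=O` has not yet been measured in this assay. It differs from compound 2 in a single place: acetyl in place of benzyl on a double-bonded ring carbon. Among the measured compounds shown here, no pair of measured compounds that differ in one place is available, so the size of this step cannot be read off directly. What the numbers do show is that the two compounds without the benzyl group, compound 1 and compound 3, both stand higher than compound 2. On that basis a moderate upward step is expected, of the size given by a number 0.34 log units higher from compound 2 to compound 4 (beyond the scatter), although a result within the scatter of compound 2 cannot be excluded. Compound 4 is therefore estimated at 4.6, with an expected range from 4.1 to 5.1.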

Compound 4, logarithm of the reciprocal of the active concentration, log(1/C): 3.48
Estimate against measurement, compound 4: 1.12 log units above; measured number outside the range, below it.
By their numbers in this assay, from the lowest: compound 4; then compound 2; then compounds 1 and 3 (each within the scatter of the next).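

In this assay, the double-bonded ring carbon next to the ring atom that bears an aziridin-1-yl group now has its first readable step: acetyl in place of benzyl gives (a number 0.78 log units lower from compound 2 to compound 4 (beyond the scatter)). The number at this position therefore depends on the group it carries, and a change from 7 heavy atoms with an aromatic ring to 3 heavy atoms with a carbonyl and no ring moves it beyond the scatter. Taking away benzyl does not by itself raise the number, which the earlier compounds could not show, as they differ from compound 2 in more than one place.

On these data alone, how a propyl chain or a benzoyl group would stand at this place remains open, and either could help separate the part played by the carbonyl from that of the aromatic ring. Nothing available here accounts for the lower number of compound 4.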